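The compounds below may be only part of what the source reports. "The series", "measured", "known", "first", "only" and "open" are said of these compounds alone.

Measured compounds and their values:
compound 1, `CNC(=O)c1cc(Oc2ccc(/C=C/c3ccccn3)cc2)ccn1`: 21600 nM
compound 2, `COc1ccc(NC(=O)c2cc(Oc3ccc(/C=C/c4ccccn4)cc3)ccn2)cc1`: 30000 nM
compound 3, `CNC(=O)c1cc(Oc2ccc(/C=C/c3ccncc3)cc2)ccn1`: 18200 nM

All three compounds share one core and were tested in a functional assay on HepG2 cells (Homo sapiens) for antiproliferative activity, read by CCK-8 assay, with a stated time of 48 h; a higher number here means a weaker inhibitor, a lower number a stronger inhibitor. Going by the values given here, compound 3 has the lowest of the three numbers, but the one measured step that reaches it is a 1.2-fold lower number from compound 1 to compound 3 (0.07 log units; within the scatter), and its gap to compound 2 is likewise within the scatter, so the three cannot be told apart with any confidence.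

Compound 4, `COc1ccc(CNC(=O)c2cc(Oc3ccc(/C=C/c4ccncc4)cc3)ccn2)cc1`, differs from compound 3 by 4-methoxyphenyl in place of hydrogen on a saturated chain carbon bound to an amide-type nitrogen. Among the compounds with values here, the one measured step that bears on this change is a 1.4-fold higher number from compound 1 to compound 2 (0.14 log units; within the scatter), where a 4-methoxyphenyl group also appears at the amide end of the molecule, though there it replaced the methyl directly on the nitrogen rather than a hydrogen on the carbon next along the chain. Within the data shown here, that step stayed within the scatter, and nothing among the measured compounds points to a larger effect for the present change. Compound 4 is therefore expected to give about 20000 nM, in a range from 8000 nM to 50000 nM. The expected step is a 1.1-fold higher number from compound 3 to compound 4 (0.04 log units; within the scatter), which is to say no change beyond the scatter.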

Compound 4, half-maximal inhibitory concentration: > 100000 nM
Compound 4 ended at the assay's limit (the forecaster's own chance of this, stated with the estimate: 10%); middle value at least 5.0-fold (0.69 log units) from the limit.
By their numbers in this assay, from the lowest: compounds 3, 1 and 2 (each within the scatter of the next). At a limit, above all of these: compound 4.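

In this assay compound 4 gives > 100000 nM, which is a limit of the assay and not a number. Placing 4-methoxyphenyl in place of hydrogen on the saturated chain carbon bound to the amide-type nitrogen gives an at least 5.4-fold higher number from compound 3 to compound 4 (0.73 log units; beyond the scatter), the only step shown that goes beyond the scatter, whereas the earlier change at the amide end gave a 1.4-fold higher number from compound 1 to compound 2 (0.14 log units; within the scatter). The amide end therefore does not tolerate every change equally, although the full size of this step cannot be read, and the value of compound 4 offers only a bound: the limit of > 100000 nM in this assay, at which 1 of the 4 values shown sits.

The compounds shown leave open whether the whole 4-methoxybenzyl group is needed for this result, or whether a plain benzyl group, a simple ethyl chain or a longer chain ending in an amine or a carboxylic acid would give a similar number. They also leave open whether 4-methoxybenzyl on the amide nitrogen would have the same outcome with pyridin-2-yl in place of pyridin-4-yl, as in compound 1.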